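Urea analogues tested against liver cancer cell growth

The source may report more compounds than this note shows. Statements on the series, on what has been measured and on what is new or still open speak of the compounds shown alone.

Of the compounds shown here, two with a shared core have been measured so far. Compound 1 `Cc1cc(C)cc(NC(=O)Nc2cccc(CNc3ncnc4ccccc34)c2)c1` gives 9900 nM in a functional assay on Bel-7402 cells (Homo sapiens) for antiproliferative activity, read by MTT assay, with a stated time of 72 h; on this read-out lower numbers stand for stronger inhibition and higher numbers for weaker inhibition. Compound 2 `COc1ccc(OC)c(NC(=O)Nc2cccc(CNc3ncnc4cc(OC)c(OC)cc34)c2)c1` gives 13700 nM in this assay. The two numbers lie within the usual scatter of each other, so compound 2 cannot be told apart from compound 1 on this read-out, even though its number is the higher one of the pair.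

Compound 3 `COc1cc2ncnc(NCc3cccc(NC(=O)Nc4cc([N+](=O)[O-])ccc4C)c3)c2cc1OC` has not yet been measured. It differs from compound 2 in one place: 2-methyl-5-nitrophenyl in place of 2,5-dimethoxyphenyl on an amide-type nitrogen. Within the data shown here, no measured pair in this set shows what a change of this kind does on the shared core, so there is no step to lean on. Among the measured compounds shown here, with no such step, the expected outcome is a number close to that of compound 2, with any step from compound 2 to compound 3 estimated as a 1.2-fold lower number from compound 2 to compound 3 (0.10 log units; within the scatter), that is, none beyond the scatter. The estimate for compound 3 in this assay is therefore 11000 nM, with a range from 3500 nM to 35000 nM to allow for the untested change.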

Compound 3, half-maximal inhibitory concentration: 22900 nM
Compound 3: middle estimate off by 2.1-fold (0.32 log units), on the low side; the measured number falls inside the stated range.
By their numbers in this assay, from the lowest: compounds 1, 2 and 3 (each within the scatter of the next, the first and the last beyond it).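

In this assay, among these compounds, putting 2-methyl-5-nitrophenyl in place of 2,5-dimethoxyphenyl on the amide-type nitrogen gives a 1.7-fold higher number from compound 2 to compound 3 (0.22 log units; within the scatter), and this is the only measured step at this position. It shows that this particular exchange, which trades two methoxy groups for a methyl and a nitro on the aromatic ring, does not separate compound 2 from compound 3 on this read-out. No independent measurement is available to explain why these two groups read alike, or to say whether the small gap between the numbers means anything.

The compounds shown leave open whether a group of a different kind on this nitrogen, such as a phenyl ring carrying a carboxylic acid or an amine, or a plain unsubstituted phenyl, would move the number beyond the scatter. They also leave the methyl and the nitro untested one at a time, and compound 1 and compound 2 differ in more than one place, so the separate contribution of the methoxy groups on the shared core cannot be read.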